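This account rests on a few compounds, and the source may have more. Where it says the series, first, only, none or still open, it means among the compounds named here.

Measured in a functional assay on MCF7 cells (Homo sapiens) for cytotoxicity, read by MTT assay, with a stated time of 72 h; on this read-out higher numbers stand for weaker inhibition and lower numbers for stronger inhibition:
- compound 1 `COc1cccc(/C=C2\CCC/C(=C\c3cccc(OC)c3OC)C2=O)c1`: 5900 nM
- compound 2 `COc1cccc(/C=C2\CCC/C(=C\c3ccc(Cl)c(Cl)c3)C2=O)c1OC`: 9000 nM
- compound 3 `COc1ccc(/C=C2\CCC/C(=C\c3ccccc3Cl)C2=O)cc1OC`: 10400 nM

Compound 3 gives 10400 nM, a number within the usual scatter of both other values, so these three compounds cannot be told apart in this assay. The next compound to be tested is compound 4 `COc1cccc(/C=C2\CCC/C(=C\c3ccc(OC)c(OC)c3)C2=O)c1`. Its structural change from compound 3 is 3-methoxyphenyl in place of 2-chlorophenyl on a double-bonded chain carbon bound to a double-bonded ring carbon, which puts 3-methoxyphenyl in place of 2-chlorophenyl on a double-bonded chain carbon bound to a double-bonded ring carbon.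

For the measured compounds named here, only one measured step bears on this change: a 1.5-fold higher number from compound 1 to compound 2 (0.18 log units; within the scatter). That step swaps 3-methoxyphenyl for 3,4-dichlorophenyl at the same kind of place, so it is the closest available comparison, read in reverse. It stays within the scatter, and it is a single pair with a different chlorinated group and a different remainder of the molecule, so it offers only weak guidance. No large effect is therefore expected, at most a slight fall in the number. The expected change is a 1.5-fold lower number from compound 3 to compound 4 (0.17 log units; within the scatter), which would not stand out from the scatter. The estimate for compound 4 is 7000 nM, with an expected range from 3200 nM to 14000 nM.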

Compound 4, half-maximal inhibitory concentration: 4600 nM
Compound 4: middle estimate off by 1.5-fold (0.18 log units), on the high side; low and high end bracket the measured number.
By their numbers in this assay, from the lowest: compounds 4, 1, 2 and 3 (each within the scatter of the next, the first and the last beyond it).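

In this assay, putting 3-methoxyphenyl in place of 2-chlorophenyl on a double-bonded chain carbon bound to a double-bonded ring carbon gives a 2.3-fold lower number from compound 3 to compound 4 (0.35 log units; beyond the scatter), and this is the one step among these compounds that passes the usual scatter of repeated measurements. The other step, a 1.5-fold higher number from compound 1 to compound 2 (0.18 log units; within the scatter), stays inside that scatter, so on its own it could not show whether the group at this kind of place affects the number; this pair shows that it can, though only modestly and in a single comparison. No measurement shown here explains the shift.

The change removes a chlorine and adds a methoxy group in one move, so this pair cannot tell whether losing the one or gaining the other accounts for the difference, or whether the same swap would have the same effect with a different remainder of the molecule. A plain phenyl group at this place would help separate those two contributions, while a phenyl group carrying an amine or a carboxylic acid would test how far the number can move here.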